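Alkoxy-pyrazole carboxamides: from compound 3 to compound 4

This account rests on a few compounds, and the source may have more. Where it says the series, first, only, none or still open, it means among the compounds named here.

Measured so far in a functional assay on the whole organism (strain Wistar) for inhibition, with Rattus norvegicus as the target, read by paw edema, with stated times of 30 min and 3 h, at a dose of 100 mg/kg by the oral route; on this read-out lower numbers stand for less inhibition and higher numbers for more inhibition at the one dose given (going by the name of the read-out):
compound 1 `COc1cc(C(N)=O)nn1-c1ccccc1` gives 34.3%
compound 2 `CCOc1cc(C(=O)N(C)C)nn1-c1ccccc1` gives 65.8%
compound 3 `CCCCOc1cc(C(N)=O)nn1-c1ccccc1` gives 26.5%

Compound 3 holds the lowest number of the three. Its nearest neighbour is compound 1, whose number lies higher by a number 7.8 percentage points lower from compound 1 to compound 3 (within the scatter) taken backwards, a gap within the scatter, so the two read as the same. For the measured compounds named here, compound 2 stands furthest, beyond the scatter, but compound 2 differs from compound 1 in two places at once, so no single step can be taken from it; its structure and value simply stand as they are.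

Compound 4 `CCCCOc1cc(C(=O)N2CCCCC2)nn1-c1ccccc1` is not yet measured. It differs from compound 3 by piperidin-1-yl in place of amino on a carbonyl carbon.

Going by the values given here, no measured step touches the carbonyl carbon. Among the compounds with values here, the one step known, a number 7.8 percentage points lower from compound 1 to compound 3 (within the scatter), concerns the chain on the oxygen and is within the scatter, so it says nothing about a change from carbamoyl to (piperidin-1-yl)carbonyl. Within the data shown here, the only hint is that compound 2, which carries a substituted carbonyl, shows the high number of the series, while both compounds with a plain carbamoyl sit low.

On that thin basis a rise is expected for compound 4 in this assay, estimated at 50% with a range from 28% to 72%, a step of a number 23.5 percentage points higher from compound 3 to compound 4 (beyond the scatter).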

Compound 4, a percentage reported as inhibition, in the whole organism at one dose (the size of the read-out at that dose, not a potency): 15.6%
Beside the measured number, compound 4's estimate is 34.4 percentage points above it; measured number below the stated range.
By their numbers in this assay, from the lowest: compound 4; then compounds 3 and 1 (each within the scatter of the next); then compound 2.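

In this assay the carbonyl carbon is now shown to be a place where a single change moves the number: piperidin-1-yl in place of amino gives a number 10.9 percentage points lower from compound 3 to compound 4 (beyond the scatter) and the direction is towards less inhibition at the one dose given. On the chain that compound 3 carries on the oxygen, a ring on the carbonyl carbon therefore does not raise the number, and the change swaps a group counted with a hydrogen-bond donor for a larger one, counted without any, containing a six-membered non-aromatic ring, two differences that this one step cannot separate. Nothing on hand bears on why the number falls.

Open, as far as these compounds go, is whether the same change gives a step of like size and direction on other chains on the oxygen, such as the shorter one of compound 1, as this step is read on one chain only. Also open, from the compounds shown here alone, is what other groups on the carbonyl carbon, such as methylamino, pyrrolidin-1-yl or morpholin-4-yl, would give, and how dimethylamino would read on the chain of compound 3 (on its own chain, compound 2 gives 65.8%).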